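This account rests on a few compounds, and the source may have more. Where it says the series, first, only, none or still open, it means among the compounds named here.

Measured compounds in a functional assay on the whole organism (Tail, strain ICR) with Mus musculus as the target, in the tail flick test, with a stated time of 60 min, at a dose of 25 umol/kg by the oral route; on this read-out lower numbers stand for a weaker effect and higher numbers for a stronger effect at the one dose given:
compound 1 `C[C@H](NC(=O)CN(c1nc(Cl)nc2[nH]cnc12)C1CC1)C(=O)OCc1ccccc1` gives 64.3%
compound 2 `CC(C)[C@H](NC(=O)CN(c1nc(Cl)nc2[nH]cnc12)C1CC1)C(=O)OCc1ccccc1` gives 55.5%
compound 3 `O=C(CN(c1nc(Cl)nc2[nH]cnc12)C1CC1)N[C@@H](CCC(=O)OCc1ccccc1)C(=O)OCc1ccccc1` gives 53.7%

Compound 3 holds the lowest of the three numbers. Its distance to compound 2, a number 1.8 percentage points lower from compound 2 to compound 3 (within the scatter), is within the scatter, so these two are not separated; only compound 1 sits clearly higher, a number 10.6 percentage points lower from compound 1 to compound 3 (beyond the scatter), a modest step. The step of a number 8.8 percentage points lower from compound 1 to compound 2 (within the scatter) is also within the scatter, so across the side-chain changes seen so far the read-out moves little.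

Compound 4 `NC(=O)CC[C@H](NC(=O)CN(c1nc(Cl)nc2[nH]cnc12)C1CC1)C(=O)OCc1ccccc1` differs from compound 3 by amino in place of benzyloxy on a carbonyl carbon. Among the measured compounds shown here, no measured step changes the group on that carbonyl carbon; the measured steps alter only the chain on the saturated carbon bound to the amide-type nitrogen, and all of them are small. They bear on the new change only indirectly, by showing that this part of the molecule has so far tolerated change with little movement in this assay. On these data alone, the expectation is therefore no step beyond the scatter, with a wide band because the change itself is untested.

The estimated step from compound 3 to compound 4 is a number 1.7 percentage points lower from compound 3 to compound 4 (within the scatter), and compound 4 is expected to give 52%, within 35% to 68%.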

Compound 4, a percentage reported as activity, at one dose (the size of the read-out at that dose, not a potency): 33.1%
The estimate for compound 4 lay 18.9 percentage points above the measured number; the whole stated range lies above it.
By their numbers in this assay, from the lowest: compound 4; then compounds 3, 2 and 1 (each within the scatter of the next, the first and the last beyond it).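

In this assay, among the compounds shown here, the group on the carbonyl carbon is the first place in this side chain where a single change gives a step of this size: amino in place of benzyloxy gives a number 20.6 percentage points lower from compound 3 to compound 4 (beyond the scatter) and exceeds every step among compounds 1, 2 and 3. The carbamoyl end also sets compound 4 apart from the other two side chains, since 2-carbamoylethyl in place of isopropyl on the saturated chain carbon gives a number 22.4 percentage points lower from compound 2 to compound 4 (beyond the scatter) and carbamoylmethyl in place of hydrogen on the saturated chain carbon gives a number 31.2 percentage points lower from compound 1 to compound 4 (beyond the scatter), so the small movement seen between compound 2 and compound 3 does not extend to this change. No measurement shown here accounts for the fall in the read-out.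

Still open, on these data alone, is whether the fall follows the loss of the benzyl ester as such or the arrival of the primary amide, which a carboxylic acid, a methyl ester or an N-methyl amide on the same carbonyl carbon would help to separate. Also open, as far as these compounds go, is whether a shorter or longer chain carrying the same carbamoyl end would behave as compound 4 does.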